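Paw edema series: hydroxy in place of chloro

This account rests on a few compounds, and the source may have more. Where it says the series, first, only, none or still open, it means among the compounds named here.

Measured compounds in a functional assay on the whole organism (strain albino) for inhibition, with Rattus norvegicus as the target, read by paw edema, with stated times of 1 h and 0.5 h, at a dose of 100 mg/kg by the oral route; on this read-out lower numbers stand for less inhibition and higher numbers for more inhibition at the one dose given (going by the name of the read-out):
compound 1 `N#Cc1c(Cl)nc(SCC(=O)Nn2c(COc3ccc(Cl)cc3Cl)nc3ccccc3c2=O)nc1-c1ccc(O)cc1` gives 67.3%
compound 2 `N#Cc1c(Nc2ccccc2)nc(SCC(=O)Nn2c(COc3ccc(Cl)cc3Cl)nc3ccccc3c2=O)nc1-c1ccccc1` gives 71.2%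
compound 3 `N#Cc1c(Nc2ccccc2)nc(SCC(=O)Nn2c(COc3ccc(Cl)cc3Cl)nc3ccccc3c2=O)nc1-c1ccc(Cl)cc1` gives 36.5%

Compound 3 stands lowest of the three, beyond the scatter from both compound 1 and compound 2. Compound 4 `N#Cc1c(Nc2ccccc2)nc(SCC(=O)Nn2c(COc3ccc(Cl)cc3Cl)nc3ccccc3c2=O)nc1-c1ccc(O)cc1` differs from compound 3 as hydroxy in place of chloro on an aromatic carbon. Within the data shown here, the one step that bears on this position is a number 34.7 percentage points lower from compound 2 to compound 3 (beyond the scatter), where the chloro entered; removing it again should recover most of that loss. Compound 1, which also carries the hydroxyphenyl though with a different group on the core, gives a number close to compound 2. A rise beyond the scatter is therefore expected in this assay, about a number 28.5 percentage points higher from compound 3 to compound 4 (beyond the scatter). Compound 4 is estimated at 65%, within 48% to 80%.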

Compound 4, a percentage reported as inhibition, in the whole organism at one dose (the size of the read-out at that dose, not a potency): 90.4%
Estimate against measurement, compound 4: 25.4 percentage points below; the measured number lies above the stated range.
By their numbers in this assay, from the lowest: compound 3; then compounds 1 and 2 (each within the scatter of the next); then compound 4.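

In this assay, hydroxy in place of chloro gives a number 53.9 percentage points higher from compound 3 to compound 4 (beyond the scatter), and hydroxy in place of hydrogen gives a number 19.2 percentage points higher from compound 2 to compound 4 (beyond the scatter), so this position moves the number both ways from the plain phenyl, given a number 34.7 percentage points lower from compound 2 to compound 3 (beyond the scatter) for chloro. With the 4-hydroxyphenyl held constant, anilino in place of chloro gives a number 23.1 percentage points higher from compound 1 to compound 4 (beyond the scatter), so the group on the core also shifts the number. No measured property of these compounds speaks to the reason for these steps. On these data alone, whether a methoxy group or an amine at this position would track hydroxy or chloro remains open.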